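The compounds below may be only part of what the source reports. "The series", "measured", "known", "first", "only" and "open" are said of these compounds alone.

Measured in a functional assay for agonist activity at Free fatty acid receptor 1 (Homo sapiens), read by FLIPR, in the presence of a further agent that is not named here; on this read-out higher numbers stand for an effect only at larger amounts of compound and lower numbers for an effect already at smaller amounts:
- compound 1 `O=C1NC(=O)C(Cc2ccc(Oc3ncc(C(F)(F)F)cc3Cl)cc2Cl)S1`: 26 nM
- compound 2 `O=C1NC(=O)C(Cc2ccc(Oc3cccc(Cl)c3)cc2)S1`: 318 nM
- compound 3 `O=C1NC(=O)C(Cc2ccc(Oc3cc(C(F)(F)F)ccn3)cc2)S1`: 237 nM

Compound 2 gives the highest number of the three. The gap to compound 3 lies within the scatter, so the two are not distinguished; compound 1 sits well apart, beyond the scatter.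

Compound 4 `Cc1cccnc1Oc1ccc(CC2SC(=O)NC2=O)cc1` follows from compound 2 by one change: 3-methylpyridin-2-yl in place of 3-chlorophenyl on an oxygen on an aromatic ring. For the measured compounds named here, no measured pair shows this exact exchange, so the expectation rests on the spread seen so far. Compound 3, also carrying a ring with one hetero atom at this oxygen, stays within scatter of compound 2, which argues for a step of only modest size from compound 2 to compound 4, if any. For compound 4 the estimated value is 200 nM, with a range from 60 nM to 700 nM, corresponding to an expected step of a 1.6-fold lower number from compound 2 to compound 4 (0.20 log units; within the scatter).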

Compound 4, half-maximal effective concentration: 1090 nM
Compound 4: the middle estimate sits 5.5-fold (0.74 log units) below what was measured; measured number above the stated range.
By their numbers in this assay, from the lowest: compound 1; then compounds 3 and 2 (each within the scatter of the next); then compound 4.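

In this assay, 3-methylpyridin-2-yl in place of 3-chlorophenyl on an oxygen on an aromatic ring gives a 3.4-fold higher number from compound 2 to compound 4 (0.53 log units; beyond the scatter). For the compounds shown here, this is the first single-change step read at this position, and it shows that the group on this oxygen is not freely exchangeable, even though the change adds only one hydrogen-bond acceptor by count. Nothing available explains the loss.

The compounds shown leave open whether the ring nitrogen, the methyl or the loss of chlorine carries the step. A 3-methylphenyl or an unsubstituted pyridin-2-yl on the same oxygen would separate these.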